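Amide ring changes in an antiproliferative series

A few compounds are considered here, and "the series" means these few. Any claim that something is new, unique, unknown or untested is made for them only; others in the source may bear on it.

Measured in a functional assay on NCI-H460 cells (Homo sapiens) for antiproliferative activity; on this read-out higher numbers stand for weaker inhibition and lower numbers for stronger inhibition:
- compound 1 `COc1ccc(S(=O)(=O)Oc2ccccc2NC(=O)c2ccncc2)cc1` gives 55 nM
- compound 2 `COc1ccc(S(=O)(=O)Oc2ccccc2NC(=O)c2ccccn2)cc1` gives 300 nM

Compound 2 holds the higher of the two numbers, so it is the weaker inhibitor of this pair. Compound 3 `COc1ccc(S(=O)(=O)Oc2ccccc2NC(=O)c2ccc3ncccc3c2)cc1` has quinolin-6-yl in place of pyridin-2-yl on a carbonyl carbon. Going by the values given here, one measured step bears on this change, at the same carbonyl carbon: a 5.5-fold higher number from compound 1 to compound 2 (0.74 log units; beyond the scatter). Among the compounds with values here, that modest step shows that this assay responds to the group placed there, but no measured compound carries quinolin-6-yl, so neither size nor direction is fixed. With compound 2 at 300 nM as the starting point, a modest step towards a lower number is expected, of similar or smaller size. The estimated change is a 2.5-fold lower number from compound 2 to compound 3 (0.40 log units; beyond the scatter). Compound 3 is estimated at 120 nM, with an expected range of 30 nM to 500 nM.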

Compound 3, half-maximal inhibitory concentration: > 10000 nM
Compound 3: only a limit was reported; the forecaster's own chance of this, stated with the estimate: 3%; middle value at least 83-fold (1.92 log units) away from the limit.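

In this assay, quinolin-6-yl in place of pyridin-2-yl on the carbonyl carbon gives an at least 33-fold higher number from compound 2 to compound 3 (1.52 log units; beyond the scatter), and quinolin-6-yl in place of pyridin-4-yl gives an at least 180-fold higher number from compound 1 to compound 3 (2.25 log units; beyond the scatter). Both steps are large, whereas the change between the two pyridinyl groups was only modest, so this position can carry far more of the read-out than that pair showed. The reading for compound 3 is a limit and not a number: the limit of > 10000 nM in this assay, at which 1 of the 3 values shown sits.

The compounds shown do not separate the extra carbon-only aromatic ring from the change in how the nitrogen-containing ring is attached. Going by these compounds, it stays open whether a plain phenyl, or a pyridin-4-yl carrying a small amine, would stay close to compound 1 or fall away as compound 3 does.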